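This account rests on a few compounds, and the source may have more. Where it says the series, first, only, none or still open, it means among the compounds named here.

Three analogues built on one shared core have been tested in an assay for inhibition of 3-hydroxy-3-methylglutaryl-coenzyme A reductase (Rattus norvegicus); on this read-out lower numbers stand for stronger inhibition and higher numbers for weaker inhibition. Compound 3 `CO[C@H]1C[C@@H](C)C=C2C=C[C@H](C)[C@H](CCC3C[C@@H](O)CC(=O)O3)[C@H]21` gives 2810 nM, the highest number of the three and therefore the weakest inhibitor among them. Compound 1 `CC(=O)O[C@H]1C[C@@H](C)C=C2C=C[C@H](C)[C@H](CCC3C[C@@H](O)CC(=O)O3)[C@H]21` gives 269 nM, and compound 2 `C[C@H]1C=C2C=C[C@H](C)[C@H](CCC3C[C@@H](O)CC(=O)O3)[C@H]2[C@@H](OCc2ccc(F)cc2)C1` gives 4.7 nM. Compound 4 `C=C(C)CO[C@H]1C[C@@H](C)C=C2C=C[C@H](C)[C@H](CCC3C[C@@H](O)CC(=O)O3)[C@H]21` has not yet been measured; it differs from compound 3 by 1-methylethenyl in place of hydrogen on a saturated chain carbon bound to an oxygen on a saturated carbon. The step that bears most directly on this change is a 600-fold higher number from compound 2 to compound 3 (2.78 log units; beyond the scatter), which removed a group from exactly the same place; read in reverse, it points toward a lower number when something is put back there. The step of a 10-fold higher number from compound 1 to compound 3 (1.02 log units; beyond the scatter) shows that this position is sensitive in both directions. The entering 1-methylethenyl is not the 4-fluorophenyl of compound 2, so the full reverse of that step is not assumed. The expected step is a 19-fold lower number from compound 3 to compound 4 (1.27 log units; beyond the scatter). The estimate for compound 4 is 150 nM, within a range from 30 nM to 800 nM.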

Compound 4, half-maximal inhibitory concentration: 360 nM
Estimate against measurement, compound 4: 2.4-fold (0.38 log units) below; measured number inside the range.
By their numbers in this assay, from the lowest: compound 2; then compounds 1 and 4 (each within the scatter of the next); then compound 3.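

Lengthening the group on this oxygen from methyl to 2-methylprop-2-en-1-yl gives a 7.8-fold lower number from compound 3 to compound 4 (0.89 log units; beyond the scatter), so a group made only of carbon, with no ring and no hydrogen-bond acceptor, is enough to lower the number at this place. That gain stays far short of the 4-fluorobenzyl group, as 1-methylethenyl in place of 4-fluorophenyl gives a 77-fold higher number from compound 2 to compound 4 (1.88 log units; beyond the scatter), so the two groups are not interchangeable here. Putting 2-methylprop-2-en-1-yl in place of acetyl gives a 1.3-fold higher number from compound 1 to compound 4 (0.13 log units; within the scatter), which shows that a carbonyl on this oxygen is not needed to reach the level of the acetyl compound.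

Nothing measured here explains any of these steps. On these data alone, it remains open whether a plain benzyl, or a saturated 2-methylpropyl chain, would fall with compound 2 or with compound 4.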